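Isopropyl on the amidine: cytotoxicity in two benzofuran series

The source may hold more compounds than are shown below. What is called first, only, known or untested is meant among the compounds shown, and "the series" means these compounds.

Measured compounds:
compound 1, `N=C(N)c1ccc2oc(-c3cccc(OCCCCCOc4ccccc4)c3)cc2c1`: 3000 nM
compound 2, `CC(C)NC(=N)c1ccc2oc(-c3cccc(OCCCCCOc4ccccc4)c3)cc2c1`: 10100 nM
compound 3, `N=C(N)c1ccc2cc(-c3ccc(OCCCCOc4ccccc4)cc3)oc2c1`: 14100 nM

All three were tested in an ADME assay on L6 cells (Rattus norvegicus) for cytotoxicity, read by resazurin assay, with a stated time of 70 h; a higher number here means a weaker inhibitor, a lower number a stronger inhibitor. Compound 1 carries an unsubstituted amidine on its core; compound 2 differs from it by isopropyl in place of hydrogen on an amine nitrogen, and the result is a 3.4-fold higher number from compound 1 to compound 2 (0.53 log units; beyond the scatter). Compound 3 belongs to a second core, and the difference between the two cores is not broken down here; its own value in this assay is the highest of the three, though compared with compound 2 it lies within the usual scatter.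

Compound 4, `CC(C)NC(=N)c1ccc2cc(-c3ccc(OCCCCOc4ccccc4)cc3)oc2c1`, has not yet been measured. It differs from compound 3 by isopropyl in place of hydrogen on an amine nitrogen, the same change that separates compound 2 from compound 1, at the same kind of position. The expectation for compound 4 rests on that single earlier step: a similar increase is expected, so that a 2.8-fold higher number from compound 3 to compound 4 (0.45 log units; beyond the scatter) is estimated. Because compound 3 already sits at 14100 nM, compound 4 is expected to come out around 40000 nM, most likely between 18000 nM and 90000 nM.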

Compound 4, half-maximal inhibitory concentration: 15900 nM
Estimate against measurement, compound 4: 2.5-fold (0.40 log units) above; the measured number lies below the stated range.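

In this assay, isopropyl in place of hydrogen on an amine nitrogen gives a 1.1-fold higher number from compound 3 to compound 4 (0.05 log units; within the scatter), so on this core the change makes no difference that can be told from the scatter. The size of the step therefore did not carry over from one core to the other, and the earlier step alone would have been a poor guide here: the same change on two cores in this assay, a 3.4-fold higher number (0.53 log units; beyond the scatter) from compound 1 to compound 2 and a 1.1-fold higher number (0.05 log units; within the scatter) from compound 3 to compound 4, 3.0-fold (0.48 log units) apart, beyond the scatter of two such steps
For the compounds shown here, this rests on only one pair of compounds per core, and the two pairs differ from each other in more than one place, so it does not show which structural difference matters or how the change would behave on any further core.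

The compounds shown leave open whether a different group on that nitrogen, such as methyl or cyclopentyl, would also give steps that differ between the two cores. They also leave open whether the gap between the steps would remain if each core carried a shorter or a longer chain.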